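This account rests on a few compounds, and the source may have more. Where it says the series, first, only, none or still open, it means among the compounds named here.

Measured so far:
- compound 1, `COc1ccc(-c2cnc3nc(N)nc(N4CCN(Cc5c(Cl)cccc5Cl)CC4)c3n2)cc1OC`, giving 7600 nM in a functional assay on cells (T-cell, Homo sapiens) for inhibition; a lower number here means a stronger inhibitor, a higher number a weaker inhibitor
- compound 2, `COc1ccc(-c2cnc3nc(N)nc(OC(C)C)c3n2)cc1OC`, giving 400 nM in this assay

Compound 1 stands at the higher of the two numbers, so it is the weaker inhibitor of this pair; compound 2 sits well below it, and that gap lies beyond the usual scatter. Going by the values given here, the two share the same core but differ in more than one place, so the two values show only that compound 2 is the stronger inhibitor, not which change matters.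

Compound 3, `COc1ccc(-c2cnc3nc(N)nc(N4CCN(c5ccccc5)CC4)c3n2)cc1OC`, has not yet been measured in this assay. It differs from compound 1 in one place: phenyl in place of 2,6-dichlorobenzyl on an amine nitrogen in a ring. The ring that carries this group is kept; only what sits on its nitrogen changes. Among the compounds with values here, none of the measured compounds shows what such a change does here, so the expectation rests on compound 1 alone. The step of a 2.2-fold lower number from compound 1 to compound 3 (0.34 log units; beyond the scatter) is expected to be modest, downward, and possibly still within the scatter. Compound 3 is expected to give 3500 nM in this assay, within a range from 900 nM to 14000 nM.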

Compound 3, half-maximal inhibitory concentration: 400 nM
Compound 3: the middle estimate sits 8.8-fold (0.94 log units) above what was measured, and the stated range ends above it.
By their numbers in this assay, from the lowest: compounds 2 and 3 (each within the scatter of the next); then compound 1.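

In this assay, putting phenyl in place of 2,6-dichlorobenzyl on an amine nitrogen in a ring gives a 19-fold lower number from compound 1 to compound 3 (1.28 log units; beyond the scatter) while the rest of the molecule stays the same. Going by these compounds alone, this is the first comparison here that isolates a single change, and it shows that the group on this nitrogen strongly affects the result: with phenyl, compound 3 gives 400 nM and the ring itself is unchanged. The change removes the chlorines and the carbon that links the aromatic ring to the nitrogen in one step, and no measurement available here explains the drop in the number or separates these two parts of the change.

An unsubstituted benzyl group would help to separate them, by keeping the carbon link without the chlorines, and a 2-chlorophenyl group would test a chlorine with no link. On these data alone, whether a group other than an aromatic ring can serve on this nitrogen also remains open, for example a methyl group, an acetyl group or a pyridine ring.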